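The source may report more compounds than this note shows. Statements on the series, on what has been measured and on what is new or still open speak of the compounds shown alone.

Three compounds have been measured:
compound 1, `COc1cccc(C(=O)Oc2cc3c(cc2C)[C@@H](C(C)C)CC=C3C)c1`, reported as "not active" (no number reported) in a functional assay on K562 cells (Homo sapiens) for antiproliferative activity, read by sulforhodamine B assay, with a stated time of 48 h, tested at 50 uM; on this read-out lower numbers stand for less inhibition and higher numbers for more inhibition at the one concentration tested (going by the name of the read-out);
compound 2, `CC1=CC[C@H](C(C)C)c2cc(C)c(OC(=O)c3ccc(C)cc3)cc21`, with 100% in this assay;
compound 3, `COc1cccc(C(=O)Oc2cc3c(C)ccc(C(C)C)c3cc2C)c1`, with 14.2% in this assay.

Compound 1 stands on no single number: it is reported as not active, so no size can be set beside it. Compound 2, which shares the core of compound 1 but carries a different group on the ester, shows a high inhibition, while compound 3, with a different core, sits far lower. Compound 4, `CC1=CC[C@H](C(C)C)c2cc(C)c(OC(=O)c3ccccc3)cc21`, differs from compound 1 in one place: hydrogen in place of methoxy on an aromatic carbon. Going by the values given here, no measured pair covers this change, so the step from compound 1 cannot be sized; since compound 1 is reported as not active and compound 2 gives 100%, a higher number in this assay than for compound 1 is expected. For compound 4 the expected inhibition is 60%, in the range 15% to 100%.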

Compound 4, a percentage reported as inhibition, at one concentration (the size of the read-out at that concentration, not a potency): "not active" (no number reported)
Compound 4 has no reported number here, and the estimate cannot be compared.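

In this assay compound 1 gives "not active" (no number reported) and compound 4 gives "not active" (no number reported) as well, so no new step can be read. As far as these compounds go, whether going from 3-methoxyphenyl to phenyl changes inhibition at all stays open. No evidence bears on this result.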